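Benzoxaborole series: cytotoxicity notes on compounds 1 to 4

The compounds below may be only part of what the source reports. "The series", "measured", "known", "first", "only" and "open" are said of these compounds alone.

Measured so far:
Compound 1, `O=[N+]([O-])c1ccc(Sc2cn(-c3ccc4c(c3)B(O)OC4)c3ccccc23)cc1`: in an ADME assay on L929 cells (Mus musculus) for cytotoxicity, read by resazurin assay, with a stated time of 72 h (on this read-out lower numbers stand for stronger inhibition and higher numbers for weaker inhibition), compound 1 gives > 10 ug/mL, which is a limit of the assay and not a number.
Compound 2, `COc1ccc(CNC(=O)c2cccn2-c2ccc3c(c2)B(O)OC3)cc1`: in this assay compound 2 gives > 10 ug/mL, again a limit.
Compound 3, `O=C(c1ccc(F)cc1)c1ccn(-c2ccc3c(c2)B(O)OC3)c1`: in this assay compound 3 gives > 10 ug/mL, also a limit.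

Compound 3 therefore stands at the limit of > 10 ug/mL in this assay, at which 3 of the 3 values shown sit; no number has been resolved for it, and the three measured compounds cannot be ordered against one another on these read-outs. Among the measured compounds shown here, no step between two measured compounds is available, so the size of any effect of a structural change in this assay is unknown from this set.

Compound 4, `CCCCCC(=O)c1ccn(-c2ccc3c(c2)B(O)OC3)c1`, is the next compound for this assay. It differs from compound 3 by pentyl in place of 4-fluorophenyl on a carbonyl carbon.

With all measured values sitting at the limit, the step that the limit leaves unreadable from compound 3 to compound 4 is expected to stay within the scatter, with no direction favoured. Compound 4 is expected to give about 15 ug/mL, in the range 7 ug/mL to 40 ug/mL, most likely again as a limit rather than a number.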

Compound 4, half-maximal inhibitory concentration: > 10 ug/mL
Compound 4 was reported as a limit; the forecaster's own chance of this, stated with the estimate: 75%; the middle value does not contradict the limit.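

Among the compounds shown here, no step from compound 3 to compound 4 can be read in this assay, because both values are limits and not numbers: the limit of > 10 ug/mL in this assay, at which 4 of the 4 values shown sit.

Left open is whether pentyl in place of 4-fluorophenyl on a carbonyl carbon changes the cytotoxicity read-out at all.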